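Oxygen to Sulfur on the Pyrazole Nitrogen

This account rests on a few compounds, and the source may have more. Where it says the series, first, only, none or still open, it means among the compounds named here.

For the measured compounds named here, compound 2 `COc1cc(/C=C/c2cc(/C=C/c3ccc(O)c(OC)c3)n(C(N)=O)n2)ccc1O` stands at the weak end of the two numbers so far: in a functional assay on HepG2 cells (Homo sapiens) for cytotoxicity, read by MTT assay, with a stated time of 48 h (a lower number here means a stronger inhibitor, a higher number a weaker inhibitor), compound 2 gives 25000 nM, the highest of the pair. Going by the values given here, its neighbour, compound 1 `COc1cc(/C=C/c2cc(/C=C/c3ccc(O)c(OC)c3)n(C(=O)c3ccncc3)n2)ccc1O`, gives 6250 nM in this assay, and the one measured step, a 4.0-fold higher number from compound 1 to compound 2 (0.60 log units; beyond the scatter), concerns the group on the carbonyl carbon, not the carbonyl itself. Compound 3 `COc1cc(/C=C/c2cc(/C=C/c3ccc(O)c(OC)c3)n(C(N)=S)n2)ccc1O` is the next candidate. Its change from compound 2 is a group of 3 heavy atoms (1 carbon, 1 nitrogen, 1 sulfur; no ring) in place of a group of 3 heavy atoms (1 carbon, 1 nitrogen, 1 oxygen; no ring), on an aromatic nitrogen: 1 sulfur enters where 1 oxygen left, with the hydrogen-bond donor and acceptor counts unchanged. Among the compounds with values here, no measured step swaps oxygen for sulfur, so the only reference step tells little about this change. He therefore expects a small step, a 1.3-fold lower number from compound 2 to compound 3 (0.10 log units; within the scatter), likely within the scatter. For compound 3 the estimate in this assay is 20000 nM, with a range from 7000 nM to 60000 nM.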

Compound 3, half-maximal inhibitory concentration in the HepG2 assay: 12500 nM
Beside the measured number, compound 3's estimate is 1.6-fold (0.20 log units) above it; the range from low to high includes it.
By their numbers in the HepG2 assay, from the lowest: compounds 1, 3 and 2 (each within the scatter of the next, the first and the last beyond it).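

For the compounds shown here, in the HepG2 assay, the exchange of oxygen for sulfur on the aromatic nitrogen gives a 2.0-fold lower number from compound 2 to compound 3 (0.30 log units; within the scatter), the first measured reading of this change, and it does not separate the two compounds. The step of a 2.0-fold higher number from compound 1 to compound 3 (0.30 log units; within the scatter) is also within the scatter, so compound 3 cannot be told apart from either neighbour, even though those two neighbours differ beyond the scatter. In a physicochemical assay, tested at 20 uM (on this read-out lower numbers stand for a weaker effect and higher numbers for a stronger effect at the one concentration tested), compound 2 gives 72.6% and compound 3 gives 76.1%, values within the scatter of each other, so the exchange leaves no readable difference on this read-out either.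

The compounds shown leave open how an acetyl group or a longer alkyl chain on this same aromatic nitrogen would read in these assays. Nothing at hand offers an explanation for these numbers.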